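This account rests on a few compounds, and the source may have more. Where it says the series, first, only, none or still open, it means among the compounds named here.

Measured so far in an assay on blood for inhibition of C-X-C chemokine receptor type 3 (Homo sapiens), with a stated time of 30 min; a lower number here means a stronger inhibitor, a higher number a weaker inhibitor:
Compound 1 `COc1ncc(-c2nc(C(F)(F)F)sc2N2CCN(C(=O)Cn3cnc4cccnc43)[C@H](C)C2)cn1` gives 158 nM.
Compound 2 `CCOc1ncc(-c2nc(C(F)(F)F)sc2N2CCN(C(=O)Cn3cnc4cccnc43)[C@H](C)C2)cn1` gives 48 nM.

Compound 2 holds the lower of the two numbers; its nearest neighbour is compound 1, separated by the step of a 3.3-fold lower number from compound 1 to compound 2 (0.52 log units; beyond the scatter). Compound 3 `CCOc1ncc(-c2nc(C(F)(F)F)sc2N2CCN(C(=O)Cn3ccc4cnccc43)[C@H](C)C2)cn1` differs from compound 2 by a group of 9 heavy atoms (7 carbon, 2 nitrogen; one five-membered aromatic ring with 1 hetero atom, one six-membered aromatic ring with 1 hetero atom) in place of a group of 9 heavy atoms (6 carbon, 3 nitrogen; one five-membered aromatic ring with 2 hetero atoms, one six-membered aromatic ring with 1 hetero atom), on a saturated chain carbon bound to a carbonyl carbon. Within the data shown here, the only measured step, a 3.3-fold lower number from compound 1 to compound 2 (0.52 log units; beyond the scatter), concerns the saturated chain carbon bound to an oxygen on an aromatic ring, not the group on the saturated chain carbon bound to a carbonyl carbon, so nothing measured bears on this change. The expectation is therefore no step beyond the scatter, with wide uncertainty, as a 1.7-fold higher number from compound 2 to compound 3 (0.22 log units; within the scatter). Compound 3 is estimated at 80 nM, within 15 nM to 450 nM.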

Compound 3, half-maximal inhibitory concentration: 25 nM
For compound 3 the middle estimate is 3.2-fold (0.51 log units) above the measured one, within the range that was stated.
By their numbers in this assay, from the lowest: compounds 3 and 2 (each within the scatter of the next); then compound 1.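

Among these compounds, compound 1 and compound 2 differ only at the saturated chain carbon bound to an oxygen on an aromatic ring, so this is the first reading at the saturated chain carbon bound to a carbonyl carbon. In this assay the exchange of ring groups there gives a 1.9-fold lower number from compound 2 to compound 3 (0.28 log units; within the scatter) and leaves the two groups indistinguishable, so the group with 2 nitrogen serves as well as the group with 3 nitrogen. No available evidence explains this result.

Still open, from the compounds shown here alone, is how a phenyl ring or an indole would compare on that same carbon.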